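Swapping 4-chlorophenyl for 2-cyanophenyl on the shared core

This account rests on a few compounds, and the source may have more. Where it says the series, first, only, none or still open, it means among the compounds named here.

Measured so far in a functional assay on a cell-free system (plasma, Oryctolagus cuniculus) for inhibition, with stated times of 5 min, 1 min and 6 min (on this read-out higher numbers stand for weaker inhibition and lower numbers for stronger inhibition), are three compounds
- compound 1 `CCOC(=O)c1c(C)nc(-c2cccc(C#N)c2)n1OCc1ccccc1Cl` gives 8710 nM
- compound 2 `CCOC(=O)c1c(C)nc(-c2cccc(C#N)c2)n1OCc1cccc(Cl)c1` gives 19400 nM
- compound 3 `CCOC(=O)c1c(C)nc(-c2cccc(C#N)c2)n1OCc1ccc(Cl)cc1` gives 6830 nM

Compound 3 belongs to the low end of these numbers. One step reaches it without leaving the scatter (a 1.3-fold lower number from compound 1 to compound 3 (0.11 log units; within the scatter)), and another comes from further off (a 2.8-fold lower number from compound 2 to compound 3 (0.45 log units; beyond the scatter)). Compound 4 `CCOC(=O)c1c(C)nc(-c2cccc(C#N)c2)n1OCc1ccccc1C#N` carries 2-cyanophenyl in place of 4-chlorophenyl (2-cyanophenyl in place of 4-chlorophenyl on a saturated chain carbon bound to an oxygen on an aromatic ring). For the measured compounds named here, no measured compound has 2-cyanophenyl at that place, so the evidence is indirect. Compound 1, with 2-chlorophenyl, is the nearest guide at 8710 nM and moving the chlorine gave only modest steps. A small rise in the number is therefore expected (a 1.5-fold higher number from compound 3 to compound 4 (0.17 log units; within the scatter)) in this assay on this evidence. Estimated for compound 4 is 10000 nM (expected range 4000 nM to 25000 nM).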

Compound 4, half-maximal inhibitory concentration: 9380 nM
Estimate against measurement, compound 4: 1.1-fold (0.03 log units) above; the measured number falls inside the stated range.
By their numbers in this assay, from the lowest: compounds 3, 1 and 4 (each within the scatter of the next); then compound 2.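

In this assay, cyano in place of chloro on an aromatic carbon gives a difference that cannot be told from the scatter (a 1.1-fold higher number from compound 1 to compound 4 (0.03 log units; within the scatter)), and 2-cyanophenyl also stays level with 4-chlorophenyl (a 1.4-fold higher number from compound 3 to compound 4 (0.14 log units; within the scatter)). The 3-chlorophenyl compound alone stands apart, with a modest step to the new compound as well (a 2.1-fold lower number from compound 2 to compound 4 (0.32 log units; beyond the scatter)). Nothing available explains these results. Going by these compounds, what remains open is whether an amine or a carboxylic acid in place of the chlorine or nitrile would move the number further than these modest steps.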